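The compounds below may be only part of what the source reports. "The series", "measured", "known", "first", "only" and "open" are said of these compounds alone.

Measured compounds:
- compound 1, `Cc1nnc(-c2ccc(-c3ccncc3)cc2)n1-c1ccccc1F` — 5900 nM
- compound 2, `CCc1nnc(-c2ccc(-c3ccccc3)cn2)n1-c1ccccc1F` — 700 nM
- compound 3, `CCc1nnc(-c2ccc(-c3ccccc3)cc2)n1-c1ccccc1C` — 300 nM

In an assay on C6 glioma cells for displacement of a labelled ligand from sodium- and chloride-dependent glycine transporter 1 (Rattus norvegicus), read by scintillation counting, with stated times of 30 min and 10 min (a lower number here means a stronger inhibitor, a higher number a weaker inhibitor), compound 3 gives 300 nM, the lowest of the three numbers. Compound 2 is the nearest to it with 700 nM, a gap beyond the scatter. Compound 1 lies furthest with 5900 nM, again well beyond the scatter. Compound 3 therefore stands as the strongest inhibitor among the three measured, though the three differ from one another in more than one place, so no single change can be read from their numbers.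

Compound 4, `CCc1nnc(-c2ccc(-c3ccccc3)cc2)n1-c1cccc(Br)c1C`, departs from compound 3 in one place: bromo in place of hydrogen on an aromatic carbon. For the measured compounds named here, no pair among the measured compounds shows a change of this kind, so there is no measured step to lean on. With only one heavy atom entering and no change in ring count, donors or acceptors, the expectation is a small step in this assay, leaning toward a somewhat lower number, but not certainly beyond the scatter. The step of a 1.5-fold lower number from compound 3 to compound 4 (0.18 log units; within the scatter) is the expected size. Compound 4 is expected to give 200 nM, with a range from 60 nM to 700 nM.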

Compound 4, half-maximal inhibitory concentration: 2200 nM
Compound 4: the middle estimate sits 11-fold (1.04 log units) below what was measured; the whole stated range lies below it.
By their numbers in this assay, from the lowest: compound 3; then compound 2; then compound 4; then compound 1.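

In this assay, bromo in place of hydrogen on an aromatic carbon, ortho to a methyl group and meta to a large group, gives a 7.3-fold higher number from compound 3 to compound 4 (0.87 log units; beyond the scatter), a rise beyond the usual scatter. For the compounds shown here, this is the first step that can be read from a change in one place, since the earlier compounds differ from one another in more than one place and could not isolate any single change. It shows that going from 2-methylphenyl to 3-bromo-2-methylphenyl, with one heavy atom added and no hydrogen-bond donor, acceptor, ring or charge, weakens inhibition in this series; no measurement at hand bears on the cause of this loss.

As far as these compounds go, whether the loss belongs to bromo itself or would also follow from a smaller atom such as fluoro, or from a different group such as methoxy or an amine on the same carbon, remains open. Also open, from the compounds shown here alone, is whether bromo on another carbon of this ring, or on a ring lacking the methyl group, would give a step of similar size.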